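The source may report more compounds than this note shows. Statements on the series, on what has been measured and on what is new or still open speak of the compounds shown alone.

Compound 1 `Cc1cc(-c2ccccc2)n(/C(N)=N/S(=O)(=O)c2cc(C)c(Cl)cc2SCc2ccccc2C(F)(F)F)n1` gives 215000 nM in a functional assay on HeLa cells (Homo sapiens) for cytotoxicity, read by MTT assay, with a stated time of 72 h (a lower number here means a stronger inhibitor, a higher number a weaker inhibitor), the highest of the three numbers in hand; compound 2 `Cc1cc(S(=O)(=O)/N=C(\N)n2nccc2-c2ccccc2)c(SCc2ccccc2C)cc1Cl` gives 17000 nM and compound 3 `Cc1cc(S(=O)(=O)/N=C(\N)n2nccc2-c2ccccc2)c(SCc2cccc(Cl)c2)cc1Cl` gives 10000 nM, both beyond the scatter from compound 1. Compound 4 `Cc1cccc(CSc2cc(Cl)c(C)cc2S(=O)(=O)/N=C(\N)n2nc(C)cc2-c2ccccc2)c1` differs from compound 1 in one place: 3-methylphenyl in place of 2-(trifluoromethyl)phenyl on a saturated chain carbon bound to a sulfur. Within the data shown here, the only measured step at this place, a 1.7-fold lower number from compound 2 to compound 3 (0.23 log units; within the scatter), lies within the scatter, so exchanging one benzyl group for another has so far moved nothing. Compounds 2 and 3 are not single-step neighbours of compound 1, so their lower numbers cannot be tied to the benzyl group alone. For compound 4 the expected step is therefore a 1.8-fold lower number from compound 1 to compound 4 (0.25 log units; within the scatter), with direction uncertain. Compound 4 is estimated at 120000 nM, range 40000 nM to 300000 nM.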

Compound 4, half-maximal inhibitory concentration: 155000 nM
Estimate against measurement, compound 4: 1.3-fold (0.11 log units) below; the measured number falls inside the stated range.
By their numbers in this assay, from the lowest: compounds 3 and 2 (each within the scatter of the next); then compounds 4 and 1 (each within the scatter of the next).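

In this assay, among these compounds, the first exchange on the core of compound 1 gives a 1.4-fold lower number from compound 1 to compound 4 (0.14 log units; within the scatter), even though the group entering on the saturated chain carbon bound to a sulfur has no fluorine and fewer heavy atoms. Like a 1.7-fold lower number from compound 2 to compound 3 (0.23 log units; within the scatter), this step leaves the number unmoved, so two benzyl exchanges on two different cores now agree. No measured property bears on this result.

Open, going by these compounds, is whether an amine or a carboxylic acid in place of the aryl group would move the number beyond the scatter. On these data alone, a longer chain at this place is equally open.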